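Alkoxy and halogen variants on a bromoacrylamide series

The source may hold more compounds than are shown below. What is called first, only, known or untested is meant among the compounds shown, and "the series" means these compounds.

Measured so far:
Compound 1, `C=C(Br)C(=O)Nc1cccc(-c2cn3nc(-c4ccc(OCC)cc4)sc3n2)c1`, 1100 nM
Compound 2, `C=C(Br)C(=O)Nc1cccc(-c2cn3nc(-c4ccc(Cl)cc4)sc3n2)c1`, 3000 nM

Both compounds were tested in a functional assay on HeLa cells (Homo sapiens) for inhibition, read by cell counting, with a stated time of 4 days; a higher number here means a weaker inhibitor, a lower number a stronger inhibitor. Among the two numbers, compound 2 has the highest; its nearest neighbour, compound 1, sits at a 2.7-fold higher number from compound 1 to compound 2 (0.44 log units; beyond the scatter), the only step measured so far, which arose from chloro in place of ethoxy on an aromatic carbon.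

Compound 3, `C=C(Br)C(=O)Nc1cccc(-c2cn3nc(Cc4ccc(OC)cc4)sc3n2)c1`, has not yet been measured in this assay. It differs from compound 2 by 4-methoxybenzyl in place of 4-chlorophenyl on an aromatic carbon. Among the compounds with values here, the single measured step bears on it in one respect: swapping an alkoxy group for chloro gave a modestly higher number, so restoring an alkoxy group might be expected to bring the number back down. Within the data shown here, the benzyl attachment, however, has no counterpart among the measured compounds, and nothing is known about its effect. Compound 3 is therefore expected to land close to compound 2 with a modest lowering, a 2.0-fold lower number from compound 2 to compound 3 (0.30 log units; within the scatter), and its estimated value is 1500 nM, with a range from 400 nM to 6000 nM.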

Compound 3, half-maximal inhibitory concentration: 2300 nM
Estimate against measurement, compound 3: 1.5-fold (0.19 log units) below; the measured number falls inside the stated range.
By their numbers in this assay, from the lowest: compound 1; then compounds 3 and 2 (each within the scatter of the next).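

In this assay the step at this aromatic carbon, next to the ring nitrogen and next to the ring sulfur, is a 1.3-fold lower number from compound 2 to compound 3 (0.12 log units; within the scatter) and so gives no separation between 4-chlorophenyl, with 7 heavy atoms and 0 hydrogen-bond acceptors, and 4-methoxybenzyl, with 9 heavy atoms and 1 hydrogen-bond acceptor. Measured against 4-ethoxyphenyl, the same group gives a 2.1-fold higher number from compound 1 to compound 3 (0.32 log units; beyond the scatter) in this assay and thus a modest separation, so compound 3 goes against any reading that an alkoxy group alone keeps the number at the level of compound 1. No supporting evidence accompanies these results to account for either step.

The compounds shown leave open whether the step from 4-ethoxyphenyl to 4-methoxybenzyl belongs to the benzyl attachment or to methoxy in place of ethoxy, as the two change together and cannot be separated here. A 4-methoxyphenyl or a 4-ethoxybenzyl group at this carbon would bear on that question, while an amine or a carboxylic acid on the outer ring remains an open variation on the shared core.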